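The compounds below may be only part of what the source reports. "The series", "measured", "known", "first", "only" and "open" are said of these compounds alone.

Compound 2 `Cc1nn(-c2ncnc3nc[nH]c23)c2c1C(OC(=O)c1ccc(F)cc1)CC(=O)N2` carries the lowest of the two numbers measured in a functional assay on HEK293 cells for agonist activity at G-protein coupled receptor 39 (Homo sapiens), read by scintillation proximity assay and inositol phosphate accumulation, with a stated time of 75 min, in the presence of a further agent that is not named here (a higher number here means that more compound is needed for the effect, a lower number that less compound is needed), where compound 2 gives 4 nM. Its nearest neighbour is compound 1 `Cc1nn(-c2ncnc3nc[nH]c23)c2c1C(OCc1ccccc1C#N)CC(=O)N2`, which in this assay gives 8 nM; the step of a 2.0-fold lower number from compound 1 to compound 2 (0.30 log units; within the scatter) lies within the usual scatter, so the two compounds cannot be told apart on these numbers. The unmeasured compound 3 `Cc1nn(-c2ncnc3nc[nH]c23)c2c1C(c1ccc(F)cc1Cl)CC(=O)N2` differs from compound 2 in one place: 2-chloro-4-fluorophenyl in place of ((4-fluorophenyl)carbonyl)oxy on a saturated ring carbon. Going by the values given here, only the step from compound 1 to compound 2 bears on this, and it changed the group on the same saturated ring carbon without moving the number beyond the scatter; compound 3, however, loses the oxygen that linked that group, which no measured step covers. The expected step of a 2.5-fold higher number from compound 2 to compound 3 (0.40 log units; beyond the scatter) is therefore small and uncertain, and compound 3 is estimated at 10 nM in this assay, with a range from 2 nM to 60 nM.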

Compound 3, half-maximal effective concentration: 9 nM
Estimate against measurement, compound 3: 1.1-fold (0.05 log units) above, and the stated range covers the measured number.
By their numbers in this assay, from the lowest: compounds 2, 1 and 3 (each within the scatter of the next, the first and the last beyond it).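

Going by these compounds alone, compound 3 is the first case here in which no oxygen links the group to the saturated ring carbon. In this assay, replacing ((4-fluorophenyl)carbonyl)oxy with 2-chloro-4-fluorophenyl gives a 2.3-fold higher number from compound 2 to compound 3 (0.35 log units; beyond the scatter), a modest change, while replacing (2-cyanobenzyl)oxy with the same group gives a 1.1-fold higher number from compound 1 to compound 3 (0.05 log units; within the scatter). Among these three compounds, then, the oxygen link is not needed for a number in the low nanomolar range, and nothing measured here accounts for the size of either step.

On these data alone, it remains open how this position would respond to a group without an aromatic ring, such as an amine, a carboxylic acid or a longer alkyl chain. A plain phenyl group would be needed to show whether the chlorine and the fluorine on the ring matter.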